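The source may report more compounds than this note shows. Statements on the series, on what has been measured and on what is new or still open speak of the compounds shown alone.

In a functional assay, with a stated time of 30 min (on this read-out higher numbers stand for weaker inhibition and lower numbers for stronger inhibition), the measured compounds stand as follows:
- compound 1 `O=C(/C=C/c1ccccc1O)CC(=O)/C=C/c1cccc(O)c1O` gives 23000 nM
- compound 2 `O=C(/C=C/c1cccc(O)c1)CC(=O)/C=C/c1cccc(O)c1O` gives 29000 nM
- compound 3 `O=C(/C=C/c1ccc(O)c(O)c1)CC(=O)/C=C/c1cc(O)ccc1O` gives 60000 nM

Of these three, compound 3 shows the highest number and so the weakest inhibition, and its value of 60000 nM lies beyond the scatter from those of both compound 1 and compound 2.

The next compound, compound 4 `O=C(/C=C/c1cc(O)ccc1O)CC(=O)/C=C/c1cc(O)ccc1O`, comes from compound 3 by one change: 2,5-dihydroxyphenyl in place of 3,4-dihydroxyphenyl on a double-bonded chain carbon bound to a double-bonded chain carbon with 2,5-dihydroxyphenyl in place of 3,4-dihydroxyphenyl on a double-bonded chain carbon bound to a double-bonded chain carbon.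

Within the data shown here, only one measured step bears on this, and only loosely. The step of a 1.3-fold higher number from compound 1 to compound 2 (0.10 log units; within the scatter) is also an exchange of one hydroxyphenyl group for another at such a place, and it stayed within the scatter. Among the measured compounds shown here, no measured pair exchanges these two dihydroxyphenyl groups, so the direction remains open. With that single small step as the guide, no step beyond the scatter is expected in this assay for this change. The step estimated here, a 1.2-fold lower number from compound 3 to compound 4 (0.08 log units; within the scatter) as expected, is accordingly small. The estimated value for compound 4 is 50000 nM with an expected range from 20000 nM to 120000 nM on this read-out.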

Compound 4, half-maximal inhibitory concentration: 57000 nM
The estimate for compound 4 lay 1.1-fold (0.06 log units) below the measured number; measured number inside the range.
By their numbers in this assay, from the lowest: compounds 1, 2, 4 and 3 (each within the scatter of the next, the first and the last beyond it).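

In this assay, moving from 3,4-dihydroxyphenyl to 2,5-dihydroxyphenyl, two groups with the same atoms joined differently, gives a 1.1-fold lower number from compound 3 to compound 4 (0.02 log units; within the scatter). Until now the only exchange at this place was one hydroxyphenyl group for another, a 1.3-fold higher number from compound 1 to compound 2 (0.10 log units; within the scatter), so the new step extends the observation to dihydroxyphenyl groups: in both exchanges shown, a different arrangement of the hydroxyl groups on the aromatic ring gives no difference that can be read beyond the scatter. No measurement at hand offers an explanation for this result.

From the compounds shown here alone, whether the same holds for other groups on a double-bonded chain carbon bound to a double-bonded chain carbon, such as a methoxy group, an amine or a carboxylic acid on the ring, or a longer chain carrying the ring, remains open. Compound 3 and compound 4 also differ from compound 1 and compound 2 in more than one place, so the gap between the first and last in the order of numbers cannot be tied to any single group.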